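Chloro in place of fluoro on the phenyl group

The compounds below may be only part of what the source reports. "The series", "measured", "known", "first", "only" and "open" are said of these compounds alone.

In a functional assay on Jurkat cells (Homo sapiens) for antiproliferative activity, read by MTT assay, with a stated time of 48 h (a higher number here means a weaker inhibitor, a lower number a stronger inhibitor), compound 1 `O=C(CCCCCn1cc(Nc2ncc(Cl)c(Nc3cccc(Cl)c3)n2)cn1)NO` gives 50 nM and compound 2 `O=C(CCCCCn1cc(Nc2ncc(Cl)c(Nc3ccc(F)cc3)n2)cn1)NO` gives 60 nM. Among the measured compounds shown here, these two values lie within the scatter of each other, so compound 2 stands level with the only other compound measured so far. Compound 3 `O=C(CCCCCn1cc(Nc2ncc(Cl)c(Nc3ccc(Cl)cc3)n2)cn1)NO` keeps the shared core and differs from compound 2 at a single place: chloro in place of fluoro on an aromatic carbon, para to a large group. For the measured compounds named here, only one measured step bears on this change, and it also altered the substituted phenyl group. Because a 1.2-fold higher number from compound 1 to compound 2 (0.08 log units; within the scatter) lies within the scatter, no shift beyond the scatter is expected in this assay for this smaller exchange. The expected change is a 1.1-fold lower number from compound 2 to compound 3 (0.04 log units; within the scatter). Compound 3 is estimated at 55 nM, with an expected range of 25 nM to 120 nM.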

Compound 3, half-maximal inhibitory concentration: 60 nM
For compound 3 the middle estimate is 1.1-fold (0.04 log units) below the measured one, within the range that was stated.
By their numbers in this assay, from the lowest: compounds 1, 2 and 3 (each within the scatter of the next).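

In this assay the exchange of fluoro for chloro on this aromatic carbon gives no change at the digits printed from compound 2 to compound 3 (within the scatter) when seen alone, which the earlier step could not show, since it changed the halogen and its place together. With chloro kept and the phenyl group changed from 3-chlorophenyl to 4-chlorophenyl, the data give a 1.2-fold higher number from compound 1 to compound 3 (0.08 log units; within the scatter) as a separate reading of the place of the halogen, so neither single change moves the number beyond the scatter in these three compounds. No measurement at hand explains this result.

The compounds shown leave open whether an amine, a carboxylic acid or a methoxy group at this position would move the number beyond the scatter. They also leave open how the number would respond to a shorter or longer chain in place of the one in the shared core.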